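The source may hold more compounds than are shown below. What is called first, only, known or untested is meant among the compounds shown, and "the series" means these compounds.

Working notes on the hydrazone-urea series. Going by the values given here, compound 1 `CN(C)CCn1cnnc1-c1cc(Oc2ccc(NC(=O)N/N=C/c3c(Cl)cccc3Cl)cc2F)ccn1` is the anchor; in a functional assay on A549 cells (Homo sapiens) for cytotoxicity, read by MTT assay, with a stated time of 72 h (on this read-out higher numbers stand for weaker inhibition and lower numbers for stronger inhibition), compound 1 gives 1410 nM, the second highest of the three numbers measured so far. Compound 2 `CN(C)CCn1cnnc1-c1cc(Oc2ccc(NC(=O)N/N=C/c3c[nH]c4ccccc34)cc2F)ccn1` gives 820 nM in this assay, and compound 3 `COc1ccc(OC)c(/C=N/NC(=O)Nc2ccc(Oc3ccnc(-c4nncn4CCN(C)C)c3)c(F)c2)c1` gives 1950 nM. The two steps from compound 1 both swap the aryl group on the carbon with a double bond to nitrogen: a 1.7-fold lower number from compound 1 to compound 2 (0.24 log units; within the scatter) and a 1.4-fold higher number from compound 1 to compound 3 (0.14 log units; within the scatter). Among the compounds with values here, only the step of a 2.4-fold higher number from compound 2 to compound 3 (0.38 log units; beyond the scatter) runs beyond the scatter.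

Compound 4 `CN(C)CCn1cnnc1-c1cc(Oc2ccc(NC(=O)N/N=C/c3ccc(F)cc3F)cc2F)ccn1` is not yet measured. The change from compound 1 to compound 4 is 2,4-difluorophenyl in place of 2,6-dichlorophenyl on a carbon with a double bond to nitrogen. It sits at the same position varied in the two steps from compound 1, which both stayed within the scatter, so no step beyond the scatter is expected in this assay for compound 4; the estimated step is a 1.0-fold lower number from compound 1 to compound 4 (0.00 log units; within the scatter). Compound 4 is therefore expected to give about 1400 nM in this assay, with a range from 600 nM to 3200 nM.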

Compound 4, half-maximal inhibitory concentration: 1870 nM
Compound 4: the middle estimate sits 1.3-fold (0.13 log units) below what was measured, within the range that was stated.
By their numbers in this assay, from the lowest: compounds 2, 1, 4 and 3 (each within the scatter of the next, the first and the last beyond it).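

In this assay the 2,4-difluorophenyl group cannot be told apart from the two substituted phenyl groups already seen on the carbon with a double bond to nitrogen: a 1.3-fold higher number from compound 1 to compound 4 (0.12 log units; within the scatter) and a 1.0-fold lower number from compound 3 to compound 4 (0.02 log units; within the scatter) both leave the number within the scatter. Compound 2 now stands apart from a second substituted phenyl, with a 2.3-fold higher number from compound 2 to compound 4 (0.36 log units; beyond the scatter) joining its earlier gap to compound 3, although compound 1 goes against this pattern because its step to compound 2 stays within the scatter. No measurement at hand accounts for these steps.

Open, as far as these compounds go, is whether an amine or a carboxylic acid on the phenyl ring would leave this group of numbers. Also open, from the compounds shown here alone, is whether plain phenyl or a longer chain at this carbon would fall with compounds 1, 3 and 4 or with compound 2.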